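Chloro in Place of Methoxy and Cell Cytotoxicity

This account rests on a few compounds, and the source may have more. Where it says the series, first, only, none or still open, it means among the compounds named here.

Compound 1 `CCOC(=O)c1c(-c2cccc(OC)c2)[nH]c2cc(C(F)(F)F)ccc2c1=O`, compound 2 `CCOC(=O)c1c(-c2cccc(Cl)c2)[nH]c2cc(C(F)(F)F)ccc2c1=O` and compound 3 `CCOC(=O)c1c(-c2cccc(-c3ccccc3)c2)[nH]c2cc(OC)c(OC)cc2c1=O` were tested in an ADME assay on BJ cells (Homo sapiens) for cytotoxicity, read by luminescence, with a stated time of 72 h; a higher number here means that more compound is needed for the effect, a lower number that less compound is needed. In this assay compound 1 reaches only a limit, > 21500 nM. Compound 2 likewise reaches only a limit, > 21500 nM. Compound 3 also reaches only a limit, > 21500 nM. The step that the two limits leave unreadable from compound 1 to compound 2 therefore cannot be read, and the change behind it is chloro in place of methoxy on an aromatic carbon. Compound 4 `CCOC(=O)c1c(-c2cccc(-c3ccccc3)c2)[nH]c2cc(Cl)c(OC)cc2c1=O` carries the same kind of change, (chloro in place of methoxy on an aromatic carbon), set on an aromatic carbon of a six-membered aromatic ring of carbon only, part of a fused or bridged system of two rings, ortho to a methoxy group, meta and para to a fused ring, rather than meta to a large group. How the core of compound 1 and the core of compound 3 differ is not broken down here. Because (the limit of > 21500 nM in this assay, at which 3 of the 3 values shown sit), compound 4 is expected to remain at the limit as well. Compound 4 is estimated at 25000 nM, with a plausible range from 10000 nM to 60000 nM. The step that the limit leaves unreadable from compound 3 to compound 4 is expected to be essentially flat.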

Compound 4, half-maximal effective concentration: > 21500 nM
Compound 4 gave a limit, no number; the forecaster's own chance of this, stated with the estimate: 80%; the middle value lies beyond the limit too.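

Compound 3 and compound 4 both stay at a limit in this assay, so no step between them can be read: the limit of > 21500 nM in this assay, at which 4 of the 4 values shown sit.

The compounds shown leave open whether chloro in place of methoxy changes cytotoxicity at all.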